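The source may report more compounds than this note shows. Statements on the series, on what has been measured and on what is new or still open speak of the compounds shown alone.

Measured compounds in the series:
compound 1, `CCn1c(=O)n(C2OC(CO)[C@@H](O)[C@H]2O)c2nc(N)nc(O)c21`, 15 uM
compound 2, `C=CCn1/c(=N\C#N)n([C@H]2OC(CO)[C@@H](O)[C@H]2O)c2cc(N)nc(O)c21`, 156 uM
compound 3, `C=CCn1c(=S)n(COCCO)c2nc(N)nc(O)c21`, 14 uM

The read-out throughout is a functional assay (B cells) with Mus musculus as the target; on this read-out lower numbers stand for an effect already at smaller amounts and higher numbers for an effect only at larger amounts of compound. In this assay compound 1 gives 15 uM, the second highest of the three numbers. Compound 3 sits nearest with 14 uM, within the usual scatter of compound 1, so the two cannot be ordered. Compound 2 stands furthest away at 156 uM, a gap beyond the scatter. Going by the values given here, no pair of measured compounds differs in only one place, so no single-point step has been measured.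

Compound 4, `Nc1nc(O)c2c(n1)n(C1OC(CO)[C@@H](O)[C@H]1O)c(=O)n2Cc1ccc([N+](=O)[O-])cc1`, has not yet been measured in this assay. Its structure departs from compound 1 by 4-nitrophenyl in place of methyl on a saturated chain carbon bound to an aromatic nitrogen; cut one bond further out, the change reads ethyl to 4-nitrobenzyl. Among the compounds with values here, nothing among the measured compounds probes a change of this kind, so the expectation rests on compound 1 alone. The step from compound 1 is expected to be small and toward a somewhat lower number, a 1.5-fold lower number from compound 1 to compound 4 (0.18 log units; within the scatter), not clearly beyond the scatter. Compound 4 is therefore estimated at 10 uM, with a range from 3 uM to 40 uM.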

Compound 4, concentration for half-maximal effect: 40 uM
For compound 4 the middle estimate is 4.0-fold (0.60 log units) below the measured one; low and high end bracket the measured number.
By their numbers in this assay, from the lowest: compounds 3 and 1 (each within the scatter of the next); then compound 4; then compound 2.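

In this assay, going by these compounds alone, 4-nitrophenyl in place of methyl on a saturated chain carbon bound to an aromatic nitrogen gives a 2.7-fold higher number from compound 1 to compound 4 (0.43 log units; beyond the scatter) and is the only single-point step so far. This shows that the number responds to the group at this position, although the step is modest. The position accepts a six-membered aromatic ring with the effect retained, yet in this one pair the change moves the number higher, not lower. No accompanying measurement accounts for the shift, so its origin stays unassigned.

One change here brings in both the aromatic ring and the nitro group, so the step cannot be divided between them; plain benzyl at this place would separate the two, and 4-methoxybenzyl would show whether the substituent on the ring matters at all. Also open, on these data alone, is whether a longer chain such as n-butyl, or a chain ending in an amine or a carboxylic acid, would stay close to compound 1 or move further away.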